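A few compounds are considered here, and "the series" means these few. Any claim that something is new, unique, unknown or untested is made for them only; others in the source may bear on it.

Compound 1, whose structure is `C=C1[C@@H](OC(C)=O)C[C@@H]2[C@](C)(COC=O)[C@H](OC(C)=O)CC[C@@]2(C)[C@@H]1C[C@@H](Nc1ccccc1C(=O)O)C1=CCOC1=O`, was tested in a functional assay on HT-29 cells (Homo sapiens) for cytotoxicity, read by sulforhodamine B assay (on this read-out higher numbers stand for weaker inhibition and lower numbers for stronger inhibition), and gave 28700 nM. This is the highest of the two numbers recorded so far. For the measured compounds named here, the only other measured compound, compound 2 with the structure `C=C1CC[C@@H]2[C@](C)(CO[Si](C)(C)C(C)(C)C)[C@H](OC(C)=O)CC[C@@]2(C)[C@@H]1C/C=C1/C(=O)OC[C@H]1OC(C)=O`, gave 4690 nM in this assay, a lower number that lies beyond the usual scatter; since the two compounds differ in more than one place, no single step can be drawn between them.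

Compound 3, with the structure `C=C1[C@@H](OC(C)=O)C[C@@H]2[C@](C)(COC=O)[C@H](OC(C)=O)CC[C@@]2(C)[C@@H]1C[C@@H](Nc1ccc(F)cc1)C1=CCOC1=O`, has not yet been measured in this assay. It is obtained from compound 1 by one change: 4-fluorophenyl in place of 2-carboxyphenyl on an amine nitrogen. The group that leaves carries one hydrogen-bond donor and one hydrogen-bond acceptor, while the group that enters carries none, so the change is not a small one in what is counted, but nothing measured here shows how such a change moves the read-out.

The step from compound 1 to compound 3 in this assay is therefore expected to be modest, a 1.9-fold lower number from compound 1 to compound 3 (0.28 log units; within the scatter), towards a somewhat lower number, without confidence that it exceeds the scatter. Compound 3 is estimated to give about 15000 nM in this assay, within a range from 4000 nM to 50000 nM.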

Compound 3, half-maximal inhibitory concentration: 20500 nM
For compound 3 the middle estimate is 1.4-fold (0.14 log units) below the measured one; low and high end bracket the measured number.
By their numbers in this assay, from the lowest: compound 2; then compounds 3 and 1 (each within the scatter of the next).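

In this assay, the exchange of 2-carboxyphenyl for 4-fluorophenyl on the amine nitrogen gives a 1.4-fold lower number from compound 1 to compound 3 (0.15 log units; within the scatter), so compound 1 and compound 3 cannot be told apart on this read-out. For the compounds shown here, the earlier compounds offered no step in one place, and this is the first view of this position: the group on the nitrogen can lose the hydrogen-bond donor and acceptor counted in 2-carboxyphenyl, and gain a fluorine, without a shift beyond the scatter, at least for this one pair. Nothing given here offers a reason for this result.

From the compounds shown here alone, the step changes two things at once, the carboxylic acid leaving and the fluorine entering, so the weight of each on its own remains open, and a plain phenyl group on this nitrogen would be needed to separate them. Also open, going by these compounds, is whether any aromatic ring is needed at this position at all, as an alkyl chain, a benzyl group or a simple amine in its place could move the read-out in ways that this single pair of compounds cannot foretell.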